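The source may hold more compounds than are shown below. What is called first, only, known or untested is meant among the compounds shown, and "the series" means these compounds.

Compound 1 `C=C1CC[C@@H]2[C@](C)(COC(C)=O)[C@H](OC(C)=O)CC[C@@]2(C)[C@H]1CC(Nc1ccc(S(=O)(=O)Nc2ccc(Cl)nn2)cc1)C1=CCOC1=O`: 100000 nM
Compound 2 `C=C1CC[C@@H]2[C@](C)(COC(C)=O)[C@H](OC(C)=O)CC[C@@]2(C)[C@H]1CC(Nc1ccc(S(=O)(=O)Nc2nccc(C)n2)cc1)C1=CCOC1=O`: 12500 nM
Compound 3 `C=C1CC[C@@H]2[C@](C)(COC(C)=O)[C@H](OC(C)=O)CC[C@@]2(C)[C@H]1CC(Nc1ccc(S(=O)(=O)Nc2ncccn2)cc1)C1=CCOC1=O`: 4040 nM

These three compounds share one core and differ only in the aromatic ring attached to a sulfonamide nitrogen. In a functional assay on CAKI-1 cells (Homo sapiens) for inhibition, read by sulforhodamine B assay, with a stated time of 48 h (on this read-out higher numbers stand for weaker inhibition of growth and lower numbers for stronger inhibition of growth), compound 1 gives 100000 nM, the highest of the three numbers, so its inhibition of growth is the weakest seen here. Compound 2 gives 12500 nM and compound 3 gives 4040 nM. Both changes away from compound 1 lowered the number: an 8.0-fold lower number from compound 1 to compound 2 (0.90 log units; beyond the scatter) and a 25-fold lower number from compound 1 to compound 3 (1.39 log units; beyond the scatter). Within the pyrimidine pair, a 3.1-fold lower number from compound 2 to compound 3 (0.49 log units; beyond the scatter).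

Compound 4 `C=C1CC[C@@H]2[C@](C)(COC(C)=O)[C@H](OC(C)=O)CC[C@@]2(C)[C@H]1CC(Nc1ccc(S(=O)(=O)Nc2nccs2)cc1)C1=CCOC1=O` has not been measured. It differs from compound 1 in one place: 1,3-thiazol-2-yl in place of 6-chloropyridazin-3-yl on a sulfonamide nitrogen. Going by the values given here, its ring differs in kind from the pyrimidin-2-yl rings of compound 2 and compound 3, so none of the measured steps follows this exact change. Still, both exchanges of the 6-chloropyridazin-3-yl for another small heteroaryl ring lowered the number well beyond the scatter. The same direction is therefore expected here, a step of modest to large size toward a lower number, with less certainty than within the pyrimidine pair. This amounts to an expected step of a 10-fold lower number from compound 1 to compound 4 (1.00 log units; beyond the scatter). Compound 4 is expected to give 10000 nM, with a range from 2500 nM to 40000 nM.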

Compound 4, concentration for total growth inhibition: 14200 nM
The estimate for compound 4 lay 1.4-fold (0.15 log units) below the measured number; low and high end bracket the measured number.
By their numbers in this assay, from the lowest: compound 3; then compounds 2 and 4 (each within the scatter of the next); then compound 1.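

Compound 4 shows that the 6-chloropyridazin-3-yl ring of compound 1 can give way to a five-membered ring on the sulfonamide nitrogen, not only to a pyrimidine ring, and that this assay still gives a 7.0-fold lower number from compound 1 to compound 4 (0.85 log units; beyond the scatter) as the result of the exchange. Ring size alone does not sort these compounds, since the 1,3-thiazol-2-yl and 4-methylpyrimidin-2-yl rings cannot be told apart, with a 1.1-fold higher number from compound 2 to compound 4 (0.06 log units; within the scatter) for that exchange. The plain pyrimidin-2-yl ring keeps its lead over the newcomer, with a 3.5-fold higher number from compound 3 to compound 4 (0.55 log units; beyond the scatter) on this change, so compound 3 still has the lowest number and the strongest inhibition of growth of the four.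

No measurement is available that would explain why these rings differ. Open questions are whether a methyl group on the 1,3-thiazol-2-yl ring would shift the number as the comparison of compound 2 and compound 3 might suggest, and whether a pyridazin-3-yl ring without its chlorine, an isoxazole ring or a plain phenyl ring on the same nitrogen would fall with the better rings or stay with compound 1.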